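This account rests on a few compounds, and the source may have more. Where it says the series, first, only, none or still open, it means among the compounds named here.

Measured in a functional assay on CHO-K1 cells for antagonist activity at transient receptor potential cation channel subfamily V member 1 (Homo sapiens), read by FLIPR; a lower number here means a stronger inhibitor, a higher number a weaker inhibitor:
Compound 1, `CC(=O)OC1CCN(c2nc(C(F)(F)F)ccc2CNC(=O)C(C)c2ccc(NS(C)(=O)=O)c(F)c2)CC1`, gives 139 nM.
Compound 2, `CC(C(=O)NCc1ccc(C(F)(F)F)nc1N1CCC(CN(C)C)CC1)c1ccc(NS(C)(=O)=O)c(F)c1`, gives 426 nM.

Going by the values given here, of these two numbers, compound 2 stands at the higher one, its nearest neighbour being compound 1, and the only measured step, a 3.1-fold higher number from compound 1 to compound 2 (0.49 log units; beyond the scatter), shows that what sits on the saturated ring carbon shifts the number by a modest amount. Compound 3, `CC(C(=O)NCc1ccc(C(F)(F)F)nc1N1CCCCCC1)c1ccc(NS(C)(=O)=O)c(F)c1`, differs from compound 2 in one place: azepan-1-yl in place of 4-((dimethylamino)methyl)piperidin-1-yl on an aromatic carbon. Among the compounds with values here, no measured step covers this exchange of one saturated ring for another; the step from compound 1 to compound 2 bears on it only in showing that changes at this part of the shared core stay modest. A modest step down, back toward the number of compound 1, is therefore expected, a 2.4-fold lower number from compound 2 to compound 3 (0.37 log units; beyond the scatter), though with wide uncertainty. For compound 3 the estimate in this assay is 180 nM, with a range from 45 nM to 700 nM.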

Compound 3, half-maximal inhibitory concentration: 25.1 nM
Compound 3: the middle estimate sits 7.2-fold (0.86 log units) above what was measured; the measured number lies below the stated range.
By their numbers in this assay, from the lowest: compound 3; then compound 1; then compound 2.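

The group on this aromatic carbon, next to the ring nitrogen, can move the number much further than the earlier pair suggested: in this assay, replacing 4-((dimethylamino)methyl)piperidin-1-yl with azepan-1-yl gives a 17-fold lower number from compound 2 to compound 3 (1.23 log units; beyond the scatter). Replacing the 4-acetoxypiperidin-1-yl group with azepan-1-yl also lowers the number, with a 5.5-fold lower number from compound 1 to compound 3 (0.74 log units; beyond the scatter), so among these three compounds the seven-membered ring gives the strongest inhibitor. No measurement shown here explains why azepan-1-yl performs better than either substituted piperidine.

This exchange changes the ring size and removes the side group together, and the compounds shown do not separate those two changes. An unsubstituted piperidin-1-yl would bear directly on that question, while pyrrolidin-1-yl or morpholin-4-yl would extend the comparison to other rings.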